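The source may hold more compounds than are shown below. What is called first, only, known or untested is meant among the compounds shown, and "the series" means these compounds.

Values in an ADME assay on L1210 cells (Mus musculus) for cytotoxicity, with a stated time of 48 h (on this read-out higher numbers stand for weaker inhibition and lower numbers for stronger inhibition), are these.

- Compound 1 `C=C1[C@H](C)CCC[C@]1(C)CC/C(C)=C/CC1=C(O)C(=O)C=C(N[C@@H](C(=O)O)C(C)C)C1=O` gives 3.4 ug/mL
- Compound 2 `C=C1[C@H](C)CCC[C@]1(C)CC/C(C)=C/CC1=C(O)C(=O)C=C(N[C@H](CO)C(=O)O)C1=O` gives 2.6 ug/mL
- Compound 3 `C=C1[C@H](C)CCC[C@]1(C)CC/C(C)=C/CC1=C(O)C(=O)C=C(OC)C1=O` gives 2.4 ug/mL

Compound 3 stands at 2.4 ug/mL in this assay and cannot be ranked against the other two, since all three numbers lie within the scatter of one another.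

Compound 4 `C=C1[C@H](C)CCC[C@]1(C)CC/C(C)=C/CC1=C(O)C(=O)C=C(N[C@H](C(=O)O)C(C)C)C1=O` has not yet been measured. Reaching it from compound 3 means placing (1-carboxy-2-methylpropyl)amino in place of methoxy on a double-bonded ring carbon while the rest of the molecule stays the same. Compound 1 carries that same group and differs from compound 4 only at the defined stereocentre.

Two measured steps replace such an amino group with methoxy: a 1.4-fold lower number from compound 1 to compound 3 (0.15 log units; within the scatter) and a 1.1-fold lower number from compound 2 to compound 3 (0.03 log units; within the scatter). Going by the values given here, the first involves the very group that enters here, run in reverse. Among the compounds with values here, neither step leaves the scatter, and no measurement yet shows what the other arrangement at the stereocentre does. No change beyond the scatter is therefore expected in this assay, at most a slightly higher number. The expected step is a 1.3-fold higher number from compound 3 to compound 4 (0.10 log units; within the scatter) and remains an estimate. Compound 4 is expected at 3 ug/mL within an estimated range of 1.5 ug/mL to 6 ug/mL before any measurement.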

Compound 4, half-maximal inhibitory concentration: 4.4 ug/mL
Compound 4: the middle estimate sits 1.5-fold (0.17 log units) below what was measured, and the stated range covers the measured number.
By their numbers in this assay, from the lowest: compounds 3, 2, 1 and 4 (each within the scatter of the next).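

In this assay, compound 4 shows that the amino acid group (1-carboxy-2-methylpropyl)amino, in its other drawn configuration, can also replace methoxy on this double-bonded ring carbon without leaving the scatter, with a 1.8-fold higher number from compound 3 to compound 4 (0.26 log units; within the scatter). Changing the side chain with this configuration held in view gives a 1.7-fold higher number from compound 2 to compound 4 (0.23 log units; within the scatter), where 1-carboxy-2-methylpropyl replaces 1-carboxy-2-hydroxyethyl on the amine nitrogen, so this change also stays within the scatter. The earlier compounds shown here offered no reading of the stereocentre, but there is now a 1.3-fold higher number from compound 1 to compound 4 (0.11 log units; within the scatter), and that step can be assigned to configuration alone because nothing else separates the two structures: the fact that compounds 1 and 4 differ only in the configuration as drawn.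

Every step among these four compounds stays within the scatter, so it remains open whether any group at this position can move the number beyond it. A plain amine without the carboxylic acid, a methyl ester in place of that acid, or a longer chain on the amine nitrogen would test this, and the mirror-image partner of compound 2 would show whether the stereocentre also makes so little difference with the 1-carboxy-2-hydroxyethyl group.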